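The source may report more compounds than this note shows. Statements on the series, on what has been measured and on what is new or still open speak of the compounds shown alone.

Measured so far in an ADME assay on microsomes from liver (Mus musculus) for metabolic stability, read by mass spectrometry, with a stated time of 10 min, tested at 0.5 uM; on this read-out lower numbers stand for a less stable compound and higher numbers for a more stable compound
compound 1 `CNc1cc(Nc2cc(C)cc(C)c2)nn2c(C(=O)NCC(C)(CO)CO)cnc12` gives 0%
compound 2 `CNc1cc(Nc2cccc(C(C)(C)C)c2)nn2c(C(N)=O)cnc12` gives 3%
compound 3 `CNc1cc(Nc2cc(F)cc(F)c2OC)nn2c(C(=O)NC[C@](C)(O)CO)cnc12` gives 44%

Compound 1 stands level with compound 2 within the usual scatter, and both lie at the bottom of this small set. Compound 3 sits well clear of compound 1, beyond the scatter. Among the measured compounds shown here, these three compounds differ in more than one place, so no measured pair isolates a single change.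

Compound 4 `CNc1cc(Nc2cc(C)cc(C)c2)nn2c(C(=O)NCC(C)(C)CO)cnc12` keeps the core of compound 1 and alters one group: hydrogen in place of hydroxy on a saturated chain carbon, three bonds along the chain from an amide-type nitrogen and an oxygen on a saturated carbon in all. The 2,2-bis(hydroxymethyl)propyl group becomes 2-(hydroxymethyl)-2-methylpropyl, with hydrogen in place of hydroxy on a saturated chain carbon.

No measurement shows this change on its own, so any expectation is tentative. Compound 1 gives 0% here and can hardly fall further, while nothing measured points to a large rise. The expected a number 3 percentage points higher from compound 1 to compound 4 (within the scatter) is a small upward one, not beyond the scatter. For compound 4 the estimate is 3% in this assay with an expected range of 0% to 12% for the measurement.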

Compound 4, percent of the compound remaining: 0%
Beside the measured number, compound 4's estimate is 3 percentage points above it, and the stated range covers the measured number.
By their numbers in this assay, from the lowest: compounds 1, 4 and 2 (each within the scatter of the next); then compound 3.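

Among the compounds shown here, measured in this assay the swap of hydroxymethyl to methyl on the side chain gives no change at the digits printed from compound 1 to compound 4 (within the scatter) and so forms the first pair that isolates one change at this position. One of the two hydroxy groups in the 2,2-bis(hydroxymethyl)propyl group can be replaced by hydrogen with no visible effect on the number. Compound 1 already sits at the very bottom of this read-out, so the pair could reveal only a gain, and none appears; any loss would stay hidden.

On these data alone, whether an amine, a carboxylic acid or a longer chain at this place would lift the number off the bottom stays open, as does the outcome of replacing the remaining hydroxy group. Nothing given here offers a measured reason for the lack of change.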